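The source may hold more compounds than are shown below. What is called first, only, known or untested is meant among the compounds shown, and "the series" means these compounds.

Among the measured compounds shown here, compound 1 `COc1cc(-c2cc(/C=C/C(=O)c3ccc(N)cc3)[nH]n2)cc(OC)c1OC` stands second highest of the three numbers known in a functional assay on 786-0 cells (Homo sapiens) for cytotoxicity, read by sulforhodamine B assay, with a stated time of 48 h, tested at 0.1 uM (on this read-out higher numbers stand for a weaker effect at the one concentration tested and lower numbers for a stronger effect), where compound 1 gives 94%. Compound 3 `COc1ccc(-c2cc(/C=C/C(=O)c3cc(OC)c(OC)c(OC)c3)[nH]n2)cc1OC` lies nearest, giving 91%, and compound 2 `COc1ccc(-c2cc(/C=C/C(=O)c3ccc(OC)c(OC)c3)[nH]n2)cc1` lies furthest, giving 102%; both gaps fall within the scatter, so the three cannot be set in order. Compound 4 `COc1ccc(C(=O)/C=C/c2cc(-c3cc(OC)c(OC)c(OC)c3)n[nH]2)cc1` has not yet been measured. It differs from compound 1 in one place: methoxy in place of amino on an aromatic carbon. For the measured compounds named here, no step between measured compounds is known for this change, and all three measured numbers sit close together at a weak effect. The expected step of a number 2 percentage points higher from compound 1 to compound 4 (within the scatter) is therefore none beyond the scatter. Compound 4 is estimated at 96% in this assay, with a range from 85% to 106%.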

Compound 4, a percentage reported as activity, at one concentration (the size of the read-out at that concentration, not a potency): 96%
Estimate against measurement, compound 4: no gap at the digits printed; low and high end bracket the measured number.
By their numbers in this assay, from the lowest: compounds 3, 1, 4 and 2 (each within the scatter of the next, the first and the last beyond it).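

In this assay, the change from 4-aminophenyl to 4-methoxyphenyl, on an aromatic carbon para to a large group, reads as a number 2 percentage points higher from compound 1 to compound 4 (within the scatter), the first step known at this position. Amino and methoxy therefore cannot be told apart here, and both compounds sit at a weak effect. No supporting measurement bears on the reason for this result. On these data alone, whether a carboxylic acid, a dimethylamino group or a longer alkoxy chain at this position would give a step beyond the scatter remains open.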